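Amide side chain swaps on a shared core

This account rests on a few compounds, and the source may have more. Where it says the series, first, only, none or still open, it means among the compounds named here.

Compound 1, `CCn1c(C(=O)NCCCN(C)C)ccc1C(CC)(CC)c1ccc(OCCC(O)(CC)CC)c(C)c1`: in an ADME assay on L02 cells (Homo sapiens) for antiproliferative activity, read by MTT assay, with a stated time of 48 h (on this read-out higher numbers stand for weaker inhibition and lower numbers for stronger inhibition), compound 1 gives 2420 nM.
Compound 2, `CCn1c(C(=O)N(CCC#N)CCC#N)ccc1C(CC)(CC)c1ccc(OCCC(O)(CC)CC)c(C)c1`: compound 2 gives 37800 nM.
Compound 3, `CCn1c(C(=O)Nc2ccc(OC(F)(F)F)cc2)ccc1C(CC)(CC)c1ccc(OCCC(O)(CC)CC)c(C)c1`: compound 3 reaches only a limit of the assay, > 50000 nM.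

Of the two plain numbers, compound 1 has the lowest, and compound 3 sits at the limit described by the limit of > 50000 nM in this assay, at which 1 of the 3 values shown sits. The three compounds share one core and differ only in the group attached to the carbonyl carbon of the amide. Both replacements of that group moved the number up sharply: a 16-fold higher number from compound 1 to compound 2 (1.19 log units; beyond the scatter), and an at least 20-fold higher number from compound 1 to compound 3 (1.31 log units; beyond the scatter). The step between compound 2 and compound 3 is small, an at least 1.3-fold higher number from compound 2 to compound 3 (0.12 log units; that floor lies within the scatter).

Compound 4, `CCn1c(C(=O)N(C)CC(=O)O)ccc1C(CC)(CC)c1ccc(OCCC(O)(CC)CC)c(C)c1`, carries a further variant at the same position: (carboxymethyl)(methyl)amino in place of (3-(dimethylamino)propyl)amino on a carbonyl carbon. Neither measured step introduced a carboxymethyl group, so the size of the effect is open, but every change so far at this position has raised the number by a large amount. A step of similar direction is therefore expected, and compound 4 is estimated to show an 8.3-fold higher number from compound 1 to compound 4 (0.92 log units; beyond the scatter). The expected value for compound 4 is 20000 nM, with a range from 5000 nM to 60000 nM.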

Compound 4, half-maximal inhibitory concentration: 2150 nM
Compound 4: the middle estimate sits 9.3-fold (0.97 log units) above what was measured; measured number below the stated range.
By their numbers in this assay, from the lowest: compounds 4 and 1 (each within the scatter of the next); then compound 2. At a limit, above all of these: compound 3.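

In this assay, for the compounds shown here, replacing (3-(dimethylamino)propyl)amino with (carboxymethyl)(methyl)amino on the carbonyl carbon gives a 1.1-fold lower number from compound 1 to compound 4 (0.05 log units; within the scatter), so this position does not raise the number with every change, as the earlier compounds alone might have suggested. Two side chains with quite different atoms can therefore give readings that cannot be told apart, while the other groups at this position remain far from compound 4, with an 18-fold lower number from compound 2 to compound 4 (1.25 log units; beyond the scatter) and an at least 23-fold lower number from compound 3 to compound 4 (1.36 log units; beyond the scatter). The value of compound 3 is a limit of the assay, so its step to compound 4 gives only a minimum size: the limit of > 50000 nM in this assay, at which 1 of the 4 values shown sits.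

The compounds shown leave open which part of the new side chain goes with the low number, for example whether a methyl ester in place of the carboxylic acid, or a hydrogen in place of the methyl on the amide nitrogen, would keep it there. They also leave open whether a longer chain ending in a carboxylic acid, or a plain propyl chain without the terminal amine, would stay near compounds 1 and 4 or move toward compound 2.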